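The source may hold more compounds than are shown below. What is called first, only, known or untested is meant among the compounds shown, and "the series" means these compounds.

Of the compounds shown here, three that share a core have been measured in an assay on COS cells for binding affinity to Alpha-1D adrenergic receptor (Homo sapiens); a lower number here means a stronger inhibitor, a higher number a weaker inhibitor. Compound 1 `CC(C)Oc1ccccc1N1CCN(CCN(C)C(=O)CN2CCCCC2=O)CC1` gives 650 nM in this assay. Compound 2 `COc1ccccc1N1CCN(CCCNC(=O)CN2CCCCC2=O)CC1` gives 10000 nM in this assay. Compound 3 `CCOC(=O)C1CCC(=O)N1CC(=O)NCCN1CCN(c2ccccc2OC(C)C)CC1` gives 260 nM in this assay, the lowest of the three numbers; its nearest neighbour is compound 1, which stands beyond the scatter above it, and compound 2 stands furthest away from it.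

Compound 4 `CC(C)Oc1ccccc1N1CCN(CCNC(=O)CN2CCCCCC2=O)CC1` has not yet been measured in this assay. It differs from compound 3 in one place: 2-oxoazepan-1-yl in place of 2-(ethoxycarbonyl)-5-oxopyrrolidin-1-yl on a saturated chain carbon bound to a carbonyl carbon. Going by the values given here, no pair of measured compounds differs in exactly this way, so the size of the step cannot be read from a measured pair. Compound 4 resembles compound 1 more closely than compound 3 does, and compound 1 gives 650 nM in this assay. The step from compound 3 to compound 4 is therefore expected to be a mild weakening, estimated as a 1.5-fold higher number from compound 3 to compound 4 (0.19 log units; within the scatter), close to the edge of the scatter. Compound 4 is expected to give about 400 nM in this assay, with a likely range from 130 nM to 1300 nM.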

Compound 4, inhibition constant: 505 nM
Compound 4: middle estimate off by 1.3-fold (0.10 log units), on the low side; the measured number falls inside the stated range.
By their numbers in this assay, from the lowest: compounds 3, 4 and 1 (each within the scatter of the next, the first and the last beyond it); then compound 2.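

In this assay, putting 2-oxoazepan-1-yl in place of 2-(ethoxycarbonyl)-5-oxopyrrolidin-1-yl on a saturated chain carbon bound to a carbonyl carbon gives a 1.9-fold higher number from compound 3 to compound 4 (0.29 log units; within the scatter), so this pair cannot be told apart. Going by these compounds alone, this is the first step read at this position, and it shows that a large change in the group, from a five-membered to a seven-membered ring, from 11 heavy atoms to 8 and from 3 hydrogen-bond acceptors to 1, need not move the number beyond the scatter. No measurement shown here explains this result.

As far as these compounds go, the step changes the ring size and removes the ethoxycarbonyl group together, so the part played by each stays unknown. From the compounds shown here alone, it is also open how a plain 2-oxopyrrolidin-1-yl group, or a carboxylic acid in place of the ethoxycarbonyl group, would behave here.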